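The source may report more compounds than this note shows. Statements on the series, on what has been measured and on what is new or still open speak of the compounds shown alone.

In an ADME assay on L1210 cells (Mus musculus) for cytotoxicity, with a stated time of 48 h (a lower number here means a stronger inhibitor, a higher number a weaker inhibitor), compound 1 `C=C1[C@H](C)CCC[C@]1(C)CC/C(C)=C/CC1=C(O)C(=O)C=C(N[C@@H](C(=O)O)C(C)C)C1=O` gives 3.4 ug/mL and compound 2 `CC1=CCC[C@](C)(CC/C(C)=C/CC2=C(O)C(=O)C=C(N[C@@H](C(=O)O)C(C)C)C2=O)[C@@H]1C` gives 3 ug/mL. Within the data shown here, these are the only two numbers so far, and they sit level: the single measured step, a 1.1-fold lower number from compound 1 to compound 2 (0.05 log units; within the scatter), lies within the scatter. That step swaps one carbon-ring group for another and leaves the amine side of the molecule untouched.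

Compound 3 `CC1=CCC[C@](C)(CC/C(C)=C/CC2=C(O)C(=O)C=C(N[C@H](C(=O)O)[C@H](C)O)C2=O)[C@@H]1C` keeps the carbon-ring group of compound 2 and changes the other end: 1-carboxy-2-hydroxypropyl in place of 1-carboxy-2-methylpropyl on an amine nitrogen. Put simply, 1-carboxy-2-hydroxypropyl stands in place of 1-carboxy-2-methylpropyl on an amine nitrogen. Among the measured compounds shown here, no measured pair varies this group, so the one known step bears on the change only weakly, and the data cannot show its direction. The best starting point is therefore compound 2 at 3 ug/mL, with no shift beyond the scatter expected in this assay, though the range must stay wide. The expected change is a 1.5-fold higher number from compound 2 to compound 3 (0.18 log units; within the scatter). For compound 3 the estimated value is 4.5 ug/mL, with an expected range from 1.5 ug/mL to 13 ug/mL.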

Compound 3, half-maximal inhibitory concentration: > 10 ug/mL
Compound 3: only a limit was reported; the forecaster's own chance of this, stated with the estimate: 10%; middle value at least 2.2-fold (0.34 log units) from the limit.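

The change from 1-carboxy-2-methylpropyl to 1-carboxy-2-hydroxypropyl on the amine nitrogen gives an at least 3.3-fold higher number from compound 2 to compound 3 (0.52 log units; beyond the scatter), so in this assay the amine side of the molecule, untouched in the earlier pair, does affect the read-out. For compound 3, the reading of > 10 ug/mL is a limit of the assay and not a number. The carbon-ring swap gave a 1.1-fold lower number from compound 1 to compound 2 (0.05 log units; within the scatter), so this change at the amine is the first shown to reach beyond the scatter, yet its full size cannot be read, because the result for compound 3 rests on a limit: the limit of > 10 ug/mL in this assay, at which 1 of the 3 values shown sits.

The compounds shown leave open whether the weaker result comes from the hydroxyl oxygen itself or from the second defined stereocentre that enters with it, as the two arrive together in a single step. They also leave open how a methoxy group at the same place, or an amide in place of the carboxylic acid, would read in this assay, and whether a longer chain on the amine nitrogen would stay level with compound 2.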